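A few compounds are considered here, and "the series" means these few. Any claim that something is new, unique, unknown or untested is made for them only; others in the source may bear on it.

Working notes on the series. In a functional assay on A549 cells (Homo sapiens) for cytotoxicity, read by MTT assay, with a stated time of 48 h (on this read-out higher numbers stand for weaker inhibition and lower numbers for stronger inhibition), compound 1 (`CC1(C)CCC[C@]2(C)[C@@H](CC[C@@](C)(O)/C=C/c3cccc([N+](=O)[O-])c3)[C@](C)(O)CC[C@@H]12`) gives 3400 nM, compound 2 (`Cc1cccc(/C=C/[C@](C)(O)CC[C@@H]2[C@@]3(C)CCCC(C)(C)[C@@H]3CC[C@@]2(C)O)c1C`) gives 3800 nM and compound 3 (`CC1(C)CCC[C@]2(C)[C@@H](CC[C@@](C)(O)/C=C/c3ccc(Cl)nc3)[C@](C)(O)CC[C@@H]12`) gives 3280 nM. Compound 3 therefore stands level with the other two, as a 1.0-fold lower number from compound 1 to compound 3 (0.02 log units; within the scatter) and a 1.2-fold lower number from compound 2 to compound 3 (0.06 log units; within the scatter) show.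

The next entry is compound 4 (`COc1cccc(/C=C/[C@](C)(O)CC[C@@H]2[C@@]3(C)CCCC(C)(C)[C@@H]3CC[C@@]2(C)O)c1OC`), which differs from compound 3 by 2,3-dimethoxyphenyl in place of 6-chloropyridin-3-yl on a double-bonded chain carbon bound to a double-bonded chain carbon. In words, 2,3-dimethoxyphenyl stands in place of 6-chloropyridin-3-yl on a double-bonded chain carbon bound to a double-bonded chain carbon.

All three measured steps exchange the group at this same place, so all three bear on the change. Besides the two above, there is a 1.1-fold higher number from compound 1 to compound 2 (0.05 log units; within the scatter). Of the measured compounds, compound 2 carries the group closest in name to the incoming one, 2,3-dimethylphenyl, and it gives 3800 nM. For the measured compounds named here, no compound with a methoxy group has been measured, so this reading is an extrapolation from three close values. No step beyond the scatter is expected in this assay, and no direction is favoured. The expected step is a 1.1-fold higher number from compound 3 to compound 4 (0.03 log units; within the scatter). For compound 4 the estimated value is 3500 nM, with an expected range of 1800 nM to 7000 nM.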

Compound 4, half-maximal inhibitory concentration: 3280 nM
Beside the measured number, compound 4's estimate is 1.1-fold (0.03 log units) above it; measured number inside the range.
By their numbers in this assay, from the lowest: compounds 3, 4, 1 and 2 (each within the scatter of the next).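

For the compounds shown here, the methoxy groups add something the earlier compounds did not show: in this assay, 2,3-dimethoxyphenyl stays within the scatter of all three earlier groups (no change at the digits printed from compound 3 to compound 4 (within the scatter); a 1.2-fold lower number from compound 2 to compound 4 (0.06 log units; within the scatter); a 1.0-fold lower number from compound 1 to compound 4 (0.02 log units; within the scatter)). The exchange of compound 3 for compound 4 is also the largest difference in make-up among these steps that is set out here, going from 6-chloropyridin-3-yl, with 7 heavy atoms, 1 hydrogen-bond acceptor and a ring with 1 hetero atom, to a carbon-only ring with 10 heavy atoms and 2 hydrogen-bond acceptors, and the printed values still do not separate the two, so across these four compounds the read-out at this place does not follow these counts. No measurement is available that accounts for this flat result.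

The compounds shown leave open whether any group on this double-bonded chain carbon can move the number beyond the scatter, since all four carry a six-membered aromatic ring there. An amine, a carboxylic acid or a longer chain in place of that ring remains the open question, as does whether the flat reading holds with a change elsewhere on the shared core.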